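This account rests on a few compounds, and the source may have more. Where it says the series, first, only, none or still open, it means among the compounds named here.

Compound 1, `N#CNC(=N)NCCCCCn1nc(-c2ccccc2)ccc1=O`, in a functional assay on the whole organism (stomach) with Rattus norvegicus as the target; a lower number here means that less compound is needed, a higher number that more compound is needed for the effect: > 100 mg/kg, which is a limit of the assay and not a number.
Compound 2, `C/N=C(\S)NCCCCCn1nc(-c2ccccc2)ccc1=O`, in this assay: 35.3 mg/kg.
Compound 3, `N#CNC(=N)NCCCCn1nc(-c2ccccc2)ccc1=O`, in this assay: 77.2 mg/kg.

All three share a core carrying a chain that ends in a nitrogen-rich group. Compound 1 and compound 2 differ only at that end: a group of 4 heavy atoms (2 carbon, 1 nitrogen, 1 sulfur; no ring) in place of a group of 5 heavy atoms (2 carbon, 3 nitrogen; no ring), on an amine nitrogen. That change gives an at least 2.8-fold lower number from compound 1 to compound 2 (0.45 log units; beyond the scatter), though the starting point is only (the limit of > 100 mg/kg in this assay, at which 1 of the 3 values shown sits), so the true size of the step is open. Compound 1 and compound 3 differ in the chain: a group of 6 heavy atoms (2 carbon, 4 nitrogen; no ring) in place of a group of 7 heavy atoms (3 carbon, 4 nitrogen; no ring), on a saturated chain carbon, four bonds along the chain from an aromatic nitrogen, giving an at least 1.2-fold lower number from compound 1 to compound 3 (0.11 log units; that floor lies within the scatter). Between compound 2 and compound 3 the number moves a 2.2-fold higher number from compound 2 to compound 3 (0.34 log units; beyond the scatter).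

Compound 4, `C/N=C(\S)NCCCCn1nc(-c2ccccc2)ccc1=O`, has not yet been measured in this assay. It differs from compound 3 by a group of 4 heavy atoms (2 carbon, 1 nitrogen, 1 sulfur; no ring) in place of a group of 5 heavy atoms (2 carbon, 3 nitrogen; no ring), on an amine nitrogen, the same change as from compound 1 to compound 2, made on the same kind of place. The two cores differ as described under the difference between compound 1 and compound 3. Because compound 1 to compound 2 shows an at least 2.8-fold lower number from compound 1 to compound 2 (0.45 log units; beyond the scatter), a step of similar direction is expected here, estimated as a 3.1-fold lower number from compound 3 to compound 4 (0.49 log units; beyond the scatter). Compound 4 is therefore expected to give about 25 mg/kg in this assay, most likely between 10 mg/kg and 60 mg/kg.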

Compound 4, dose for half-maximal effect: 28.9 mg/kg
Estimate against measurement, compound 4: 1.2-fold (0.06 log units) below, and the stated range covers the measured number.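

On the core of compound 3, putting the sulfur-containing end group in place of the nitrogen-rich one gives a 2.7-fold lower number from compound 3 to compound 4 (0.43 log units; beyond the scatter) in this assay. Set beside the earlier case, the change points the same way on both chain lengths, although two cores are a small basis for calling it transferable: the same change on two cores in this assay, an at least 2.8-fold lower number (0.45 log units; beyond the scatter) from compound 1 to compound 2 and a 2.7-fold lower number (0.43 log units; beyond the scatter) from compound 3 to compound 4; the limit leaves it open whether they differ. It does not show that the size of the step is the same on both cores, since compound 1 stands at a limit of the assay and not at a number: the limit of > 100 mg/kg in this assay, at which 1 of the 4 values shown sits.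

With the sulfur-containing end group in place, the chain difference gives a 1.2-fold lower number from compound 2 to compound 4 (0.09 log units; within the scatter), whereas an at least 3.4-fold lower number from compound 1 to compound 4 (0.53 log units; beyond the scatter) joins the chain difference and the end-group change, so this step alone cannot divide the effect between them. Still open, on these data alone, is whether the end-group change would hold on a longer chain or a much shorter one, and how a simple amine or a urea at the chain end would compare with these two end groups.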